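Swapping the aryl amide substituent: from methyl to fluorine

The compounds below may be only part of what the source reports. "The series", "measured", "known", "first", "only" and "open" are said of these compounds alone.

Measured in a functional assay on CHO cells for antagonist activity at Orexin receptor type 2 (Homo sapiens), read by FLIPR and calcium flux; a lower number here means a stronger inhibitor, a higher number a weaker inhibitor:
- Compound 1 `Cc1cccc(C)c1NC(=O)CSc1nnc(-c2ccoc2C)n1Cc1ccco1` gives only a limit, > 15800 nM.
- Compound 2 `Cc1occc1-c1nnc(SCC(=O)Nc2ccc(F)c(Cl)c2)n1Cc1ccco1` gives 39.8 nM.
- Compound 3 `Cc1cccc(NC(=O)CSc2nnc(-c3ccoc3C)n2Cc2ccco2)c1` gives 50.1 nM.

Compound 3 has the higher of the two real numbers, but its gap to compound 2 is within the scatter: a 1.3-fold higher number from compound 2 to compound 3 (0.10 log units; within the scatter). Compound 4 `Cc1occc1-c1nnc(SCC(=O)Nc2ccc(F)cc2)n1Cc1ccco1` differs from compound 3 by 4-fluorophenyl in place of 3-methylphenyl on an amide-type nitrogen. Within the data shown here, the steps that bear on this change are the two large ones away from compound 1, an at least 310-fold lower number from compound 1 to compound 3 (2.49 log units; beyond the scatter) and an at least 390-fold lower number from compound 1 to compound 2 (2.59 log units; beyond the scatter), which only show that the 2,6-dimethylphenyl group is unfavourable, and the small one, a 1.3-fold higher number from compound 2 to compound 3 (0.10 log units; within the scatter), which shows that exchanging substituents on the phenyl ring changed little. Compound 4 is therefore expected to stay close to compound 3, with a step of a 1.6-fold higher number from compound 3 to compound 4 (0.20 log units; within the scatter) in this assay. The estimate for compound 4 is 80 nM, between 25 nM and 300 nM.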

Compound 4, inhibition constant: 158 nM
The estimate for compound 4 lay 2.0-fold (0.30 log units) below the measured number; low and high end bracket the measured number.
By their numbers in this assay, from the lowest: compounds 2 and 3 (each within the scatter of the next); then compound 4. At a limit, above all of these: compound 1.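

The fluorine-for-methyl exchange is not neutral at this amide-type nitrogen: a 3.2-fold higher number from compound 3 to compound 4 (0.50 log units; beyond the scatter) is a real though modest loss, whereas compound 2 and compound 3 had stayed within the scatter of each other. The chloro also counts, since removing it gives a 4.0-fold higher number from compound 2 to compound 4 (0.60 log units; beyond the scatter). Even so, the 2,6-dimethylphenyl group remains much the poorer choice, with an at least 100-fold lower number from compound 1 to compound 4 (2.00 log units; beyond the scatter), a step read from a limit. Still open, going by these compounds, is how a methoxy group or a carboxylic acid on the phenyl ring would behave.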